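From an aryl tail to a trifluoromethyl group

The source may report more compounds than this note shows. Statements on the series, on what has been measured and on what is new or still open speak of the compounds shown alone.

Compound 1, `COc1ccccc1-c1cccc(S(=O)(=O)N2CCC(N3CCC(C)CC3)CC2)c1`: in an ADME assay on HCT-116 cells (Homo sapiens) for cytotoxicity, read by CellTiter-Glo, with a stated time of 72 h (on this read-out higher numbers stand for weaker inhibition and lower numbers for stronger inhibition), compound 1 gives > 5000 nM, which is a limit of the assay.
Compound 2, `Cc1ccc(-c2cccc(S(=O)(=O)N3CCC(N4CCC(C)CC4)CC3)c2)cc1`: in this assay compound 2 gives > 5000 nM, also a limit.
Compound 3, `COc1cc(C)ccc1S(=O)(=O)N1CCC(N2CCC(C)CC2)CC1`: in this assay compound 3 gives > 5000 nM, again a limit.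

Compound 2 stands only at a limit in this assay, as do the two other compounds; the step that the two limits leave unreadable from compound 1 to compound 2 is therefore unreadable. Going by the values given here, the one piece of evidence is the limit of > 5000 nM in this assay, at which 3 of the 3 values shown sit. Compound 4, `CC1CCN(C2CCN(S(=O)(=O)c3cccc(C(F)(F)F)c3)CC2)CC1`, differs from compound 2 by trifluoromethyl in place of 4-methylphenyl on an aromatic carbon. No measured step can be read, so no shift beyond the scatter is expected; compound 4 is estimated to sit near the same limit, with an expected step that the limit leaves unreadable from compound 2 to compound 4. Compound 4 is thus estimated at 8000 nM, within 3000 nM to 30000 nM, in this assay.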

Compound 4, half-maximal inhibitory concentration: > 5000 nM
Compound 4 ended at the assay's limit; the forecaster's own chance of this, stated with the estimate: 75%; the middle value does not contradict the limit.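

Going by these compounds alone, compound 1, compound 2 and compound 4 all stand only at a limit in this assay, so no step among them can be read. The compounds shown leave open whether trifluoromethyl, 4-methylphenyl or 2-methoxyphenyl makes any difference to the read-out: the limit of > 5000 nM in this assay, at which 4 of the 4 values shown sit.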